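Heptynyl in place of thiophene on the core of compound 1

The compounds below may be only part of what the source reports. "The series", "measured", "known", "first", "only" and "open" are said of these compounds alone.

Measured so far in a functional assay on MCF7 cells (Homo sapiens) for antiproliferative activity, read by MTT assay, with a stated time of 72 h; on this read-out higher numbers stand for weaker inhibition and lower numbers for stronger inhibition:
Compound 1, `O=c1[nH]c(=O)n(CCC(CO)CO)cc1-c1cccs1`, gives 6000 nM.
Compound 2, `CC(=O)OCC(CCn1cc(C#Cc2ccc(Br)cc2)c(=O)n(C(=O)c2ccccc2)c1=O)COC(C)=O`, gives 28900 nM.
Compound 3, `CCCCCCCCC#Cc1cn(CCC(COC(C)=O)COC(C)=O)c(=O)n(C(=O)c2ccccc2)c1=O`, gives 28900 nM.

Compound 1 holds the lowest number of the three, and its gap to compound 2 and to compound 3 lies beyond the scatter in each case, while compounds 2 and 3 sit within the scatter of each other. Compound 4, `CCCCCC#Cc1cn(CCC(CO)CO)c(=O)[nH]c1=O`, is not yet measured; it differs from compound 1 in one place: hept-1-yn-1-yl in place of thiophen-2-yl on an aromatic carbon. Going by the values given here, the only measured step that touches a group on a triple-bonded carbon is no change at the digits printed from compound 2 to compound 3 (within the scatter), where 4-bromophenyl gave way to octyl without any change in this assay. Among the compounds with values here, that step was taken on compounds carrying acetyl and benzoyl groups that compound 1 and compound 4 lack, and no measured pair swaps an aromatic ring on the core for an alkynyl chain. The expectation therefore leans on the flat outcome of that single step and is held loosely: for compound 4 a step of a 1.3-fold higher number from compound 1 to compound 4 (0.12 log units; within the scatter) is expected, no change beyond the scatter. Compound 4 is estimated at 8000 nM, within 2500 nM to 25000 nM.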

Compound 4, half-maximal inhibitory concentration: 37800 nM
Compound 4: middle estimate off by 4.7-fold (0.67 log units), on the low side; measured number outside the range, above it.
By their numbers in this assay, from the lowest: compound 1; then compounds 2, 3 and 4 (each within the scatter of the next).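

In this assay, hept-1-yn-1-yl in place of thiophen-2-yl on this aromatic carbon gives a 6.3-fold higher number from compound 1 to compound 4 (0.80 log units; beyond the scatter), so the group at this place does register on the core with free hydroxyl groups and the amide hydrogen. This contrasts with the flat step on the acetyl and benzoyl compounds, no change at the digits printed from compound 2 to compound 3 (within the scatter), which therefore does not carry over to the exchange of a ring for an alkynyl chain here. Nothing at hand explains the shift.

Open, as far as these compounds go, is whether the ring or the chain drives the gap: a furan-2-yl ring or a shorter chain such as prop-1-yn-1-yl at this carbon would help separate the two. Also open, from the compounds shown here alone, is whether the same exchange holds once acetyl and benzoyl groups are present.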